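Adding a Third Methoxy Group to Compound 3

The compounds below may be only part of what the source reports. "The series", "measured", "known", "first", "only" and "open" are said of these compounds alone.

Three compounds share one core. Compound 1 `Nc1cc(N)c2nc(-c3ccccc3)c(Oc3ccc(Cl)c(Cl)c3)nc2c1` gives 38000 nM in a functional assay on HOP-62 cells (Homo sapiens) for inhibition, read by sulforhodamine B assay, with a stated time of 48 h; a lower number here means a stronger inhibitor of growth, a higher number a weaker inhibitor of growth. Compound 2 `Nc1cc(N)c2nc(-c3ccccc3)c(NCc3ccc(Cl)c(Cl)c3)nc2c1` gives 31600 nM in this assay, and compound 3 `COc1ccc(CNc2nc3cc(N)cc(N)c3nc2-c2ccccc2)cc1OC` gives 34700 nM in this assay. Compound 3 stands second highest of the three numbers; its nearest neighbour is compound 1 and compound 2 is furthest, yet all three sit within the scatter of one another. Within the data shown here, the one single-point step measured so far, a 1.1-fold higher number from compound 2 to compound 3 (0.04 log units; within the scatter), also lies within the scatter. Compound 4 `COc1cc(CNc2nc3cc(N)cc(N)c3nc2-c2ccccc2)cc(OC)c1OC` differs from compound 3 by methoxy in place of hydrogen on an aromatic carbon. Among the measured compounds shown here, no measured step tests the addition of a methoxy group, and the only step available stayed within the scatter, so no shift beyond the scatter is expected, a 1.0-fold higher number from compound 3 to compound 4 (0.00 log units; within the scatter). Compound 4 is therefore estimated at 35000 nM, with a range from 17000 nM to 70000 nM.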

Compound 4, concentration for total growth inhibition: < 50200 nM
Compound 4 was reported as a limit; the forecaster's own chance of this, stated with the estimate: 10%; the middle value is on the limit's open side.
By their numbers in this assay, from the lowest: compounds 2, 3 and 1 (each within the scatter of the next).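

Compound 4 is reported only as a limit, < 50200 nM, so the step from compound 3 to compound 4 cannot be read. The compounds shown leave open whether methoxy in place of hydrogen on this aromatic carbon shifts the number in this assay at all.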